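The source may hold more compounds than are shown below. What is called first, only, known or untested is meant among the compounds shown, and "the series" means these compounds.

Among the compounds with values here, compound 2 `CC1(c2ccc(-c3ccccc3C#N)cc2)CC(S(=O)(=O)c2ccc(F)cc2)=C(c2ccc(/C(N)=N\O)cc2)O1` is one of two compounds measured so far in an ADME assay on J774.A1 cells (Mus musculus) for cytotoxicity, read by MTT assay, with a stated time of 72 h; on this read-out higher numbers stand for lower toxicity in this test and lower numbers for higher toxicity in this test; there compound 2 gives 9290 nM, the smaller of the two numbers, a difference within the usual scatter of compound 1 `N/C(=N/O)c1ccc(C2=C(S(=O)(=O)c3ccc(F)cc3)CC(c3ccccc3)(c3ccccc3)O2)cc1`, which gives 10200 nM. Compound 3 `CC1(c2ccccc2)CC(S(=O)(=O)c2ccc(F)cc2)=C(c2ccc(/C(N)=N\O)cc2)O1` differs from compound 2 in one place: hydrogen in place of 2-cyanophenyl on an aromatic carbon. Within the data shown here, no step between measured compounds is available to guide this, so in this assay the expected step is a 1.2-fold higher number from compound 2 to compound 3 (0.07 log units; within the scatter), none beyond the scatter in either direction. Compound 3 is therefore estimated to give 11000 nM, with a likely range between 4000 nM and 30000 nM.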

Compound 3, half-maximal cytotoxic concentration: 29700 nM
Beside the measured number, compound 3's estimate is 2.7-fold (0.43 log units) below it; low and high end bracket the measured number.
By their numbers in this assay, from the lowest: compounds 2 and 1 (each within the scatter of the next); then compound 3.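

In this assay hydrogen in place of 2-cyanophenyl on the aromatic carbon gives a 3.2-fold higher number from compound 2 to compound 3 (0.50 log units; beyond the scatter) and so points to lower toxicity in this test, showing that this position can move the read-out beyond the scatter. Methyl in place of phenyl on a saturated ring carbon gives a 2.9-fold higher number from compound 1 to compound 3 (0.46 log units; beyond the scatter) as a second step beyond the scatter, at a different place. Nothing available explains either step. From the compounds shown here alone, whether a small group such as fluorine or methoxy on that aromatic carbon would keep the higher number remains open, as does the effect of an amine there.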